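Rearranging the five-membered ring on compound 2

This account rests on a few compounds, and the source may have more. Where it says the series, first, only, none or still open, it means among the compounds named here.

Measured compounds:
compound 1 `Cc1nc(S(C)(=O)=O)ccc1Oc1ncnc(OC2CCN(C(=S)OC(C)C)CC2)c1F` — 69.9 nM
compound 2 `Cc1nc(S(C)(=O)=O)ccc1Oc1ncnc(OC2CCN(C(=O)c3noc(C(C)(C)F)n3)CC2)c1F` — 14 nM

Going by the values given here, in a functional assay on isolated protein for inhibition of Glucose-dependent insulinotropic receptor (Homo sapiens), read by HTRF and cAMP accumulation (on this read-out higher numbers stand for an effect only at larger amounts of compound and lower numbers for an effect already at smaller amounts), compound 2 holds the lowest of the two numbers; the only measured step, a 5.0-fold lower number from compound 1 to compound 2 (0.70 log units; beyond the scatter), sets it apart from compound 1. Compound 3 `Cc1nc(S(C)(=O)=O)ccc1Oc1ncnc(OC2CCN(C(=O)c3nc(C(C)(C)F)no3)CC2)c1F` keeps every atom of compound 2 and joins them differently: a group of 9 heavy atoms (5 carbon, 2 nitrogen, 1 oxygen, 1 fluorine; one five-membered aromatic ring with 3 hetero atoms) in place of a group of 9 heavy atoms (5 carbon, 2 nitrogen, 1 oxygen, 1 fluorine; one five-membered aromatic ring with 3 hetero atoms), on a carbonyl carbon. Among the compounds with values here, no measured step bears on this change. Within the data shown here, the single step from compound 1 to compound 2 concerns the replacement of a group without a ring by the ring-bearing group on the amine nitrogen, not a rearrangement within that ring, so it offers no guide to the direction or size of the move to compound 3. For compound 3 the expected step is therefore none beyond the scatter, a 1.1-fold higher number from compound 2 to compound 3 (0.06 log units; within the scatter). Compound 3 is estimated at 16 nM, with a range from 6 nM to 45 nM.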

Compound 3, half-maximal effective concentration: 43.4 nM
For compound 3 the middle estimate is 2.7-fold (0.43 log units) below the measured one; the measured number falls inside the stated range.
By their numbers in this assay, from the lowest: compound 2; then compounds 3 and 1 (each within the scatter of the next).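

In this assay, the atoms of the five-membered aromatic ring are not enough to fix the result at this carbonyl carbon: joining the same atoms differently gives a 3.1-fold higher number from compound 2 to compound 3 (0.49 log units; beyond the scatter). The replacement on the amine nitrogen also looks different now. Alongside a 5.0-fold lower number from compound 1 to compound 2 (0.70 log units; beyond the scatter) stands a 1.6-fold lower number from compound 1 to compound 3 (0.21 log units; within the scatter), so the step beyond the scatter holds for one arrangement of the ring and not for the other. Nothing available explains this difference between the two arrangements.

Only these two ring arrangements are shown, both carrying the same fluorine-bearing side group, so it remains open whether the step would persist with a cyclopropyl group in its place. Also open, from the compounds shown here alone, is how a phenyl ring on the same carbonyl carbon would compare.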